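The compounds below may be only part of what the source reports. "The series", "measured", "known", "first", "only" and "open" are said of these compounds alone.

Compound 2 `Cc1cc(S(=O)(=O)/N=C(\N)n2nccc2-c2ccccc2)c(SCc2ccccc2)cc1Cl` and compound 1 `Cc1cc(S(=O)(=O)/N=C(\N)n2nccc2-c2ccccc2)c(SCc2ccc(C(F)(F)F)cc2)cc1Cl` share one core and differ only in a benzyl substituent. In a functional assay on MCF7 cells (Homo sapiens) for cytotoxicity, read by MTT assay, with a stated time of 72 h (on this read-out lower numbers stand for stronger inhibition and higher numbers for weaker inhibition), compound 1 gives 25000 nM, and compound 2 gives 20000 nM. Within the data shown here, compound 2 thus holds the lowest of the two numbers, yet its only neighbour, compound 1, sits within the scatter of it, and the step of a 1.3-fold lower number from compound 1 to compound 2 (0.10 log units; within the scatter) is too small to call a change.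

Compound 3 `Cc1cc(S(=O)(=O)/N=C(\N)n2nccc2-c2ccccc2)c(SCc2ccccc2C(F)(F)F)cc1Cl` is the next step: trifluoromethyl in place of hydrogen on an aromatic carbon. Among the measured compounds shown here, the only measured step that bears on it is a 1.3-fold lower number from compound 1 to compound 2 (0.10 log units; within the scatter), which moved the same group on the same ring and stayed within the scatter. For the measured compounds named here, with this one step as the sole guide, a trifluoromethyl entering ortho to a large group is expected to leave the number in this assay roughly where compound 2 stands, with no step beyond the scatter in either direction. Compound 3 is therefore expected to give 22000 nM, in the range 10000 nM to 50000 nM, an expected step of a 1.1-fold higher number from compound 2 to compound 3 (0.04 log units; within the scatter).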

Compound 3, half-maximal inhibitory concentration: 21000 nM
Beside the measured number, compound 3's estimate is 1.0-fold (0.02 log units) above it; the measured number falls inside the stated range.
By their numbers in this assay, from the lowest: compounds 2, 3 and 1 (each within the scatter of the next).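

In this assay, among these compounds, the step of a 1.1-fold higher number from compound 2 to compound 3 (0.02 log units; within the scatter) lies within the scatter, so trifluoromethyl ortho to a large group, a placement the earlier compounds did not include, cannot be told apart from hydrogen on this ring. The step of a 1.2-fold lower number from compound 1 to compound 3 (0.08 log units; within the scatter), which places 2-(trifluoromethyl)phenyl where compound 1 carries 4-(trifluoromethyl)phenyl, also lies within the scatter, so these two placements of the group cannot be told apart either, and compounds 1, 2 and 3 form a single group on this read-out. No measured evidence here offers an explanation for this result.

The compounds shown leave open whether a group other than trifluoromethyl, such as an amine or a carboxylic acid on the same ring, would carry the number beyond the scatter. They also leave open whether a longer chain in place of the benzyl on the sulfur would do so, as all the steps shown concern only trifluoromethyl and hydrogen on this one ring.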